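The source may report more compounds than this note shows. Statements on the series, on what has been measured and on what is new or still open speak of the compounds shown alone.

Working notes on the series, all read in a functional assay on NCI/ADR-RES cells (Homo sapiens) for inhibition, read by luminescence, with a stated time of 72 h; on this read-out lower numbers stand for stronger inhibition and higher numbers for weaker inhibition. Compound 3 (`Nc1ncnc2c1nc(Sc1cc3c(cc1Br)OCCO3)n2CCC1CCN(C=O)CC1`) gives 2100 nM, within the scatter of compound 1 (`Nc1ncnc2c1nc(Sc1cc3c(cc1Br)CCO3)n2CCC1CCN(C=O)CC1`) at 1800 nM. Compound 2 (`Nc1ncnc2c1nc(Sc1cc3c(cc1Br)CCC3)n2CCC1CCN(C=O)CC1`) gives 230 nM, a lower number than either, beyond the scatter.

Compound 4 (`C[C@@H](O)C(=O)N1CCC(CCn2c(Sc3cc4c(cc3Br)OCCO4)nc3c(N)ncnc32)CC1`) differs from compound 3 in one place: 1-hydroxyethyl in place of hydrogen on a carbonyl carbon. In words, this is 1-hydroxyethyl in place of hydrogen on a carbonyl carbon, turning formyl into (1-hydroxyethyl)carbonyl.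

Among the measured compounds shown here, the only measured step, a 7.8-fold lower number from compound 1 to compound 2 (0.89 log units; beyond the scatter), is a change in the group on a sulfur, so it bears only indirectly. It shows how far one change can move this read-out but gives no direction for the present change. For the measured compounds named here, no measured pair varies the formyl group.

With no evidence for a direction, no shift beyond the scatter is expected, and the estimated step is a 1.1-fold lower number from compound 3 to compound 4 (0.04 log units; within the scatter). For compound 4 the estimated value is 1900 nM, with an expected range of 650 nM to 5500 nM.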

Compound 4, half-maximal inhibitory concentration: 9800 nM
Compound 4: the middle estimate sits 5.2-fold (0.71 log units) below what was measured; the measured number lies above the stated range.
By their numbers in this assay, from the lowest: compound 2; then compounds 1 and 3 (each within the scatter of the next); then compound 4.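

In this assay, 1-hydroxyethyl in place of hydrogen on a carbonyl carbon gives a 4.7-fold higher number from compound 3 to compound 4 (0.67 log units; beyond the scatter) and turns formyl into (1-hydroxyethyl)carbonyl. Among the compounds shown here, this is the first measured step at this end of the series, since the earlier step changed only the group on a sulfur, and it shows that the read-out responds to a change at this carbonyl carbon, here towards weaker inhibition. Nothing measured in the series accounts for the size or direction of this step.

One step cannot separate the contribution of the hydroxyl group from that of the added carbons or the defined stereocentre. On these data alone, it remains open how an acetyl group or an amine-bearing chain on this carbonyl carbon would read, and whether the same change would move compound 2 in the same direction.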